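The compounds below may be only part of what the source reports. "The series", "measured", "known", "first", "only" and "open" are said of these compounds alone.

Measured so far in a functional assay on MKN-45 cells (Homo sapiens) for antiproliferative activity, tested at 1 uM; on this read-out higher numbers stand for more inhibition at the one concentration tested (going by the name of the read-out) and lower numbers for less inhibition:
compound 1 `Cc1nn(C)c(Oc2ccc(Cl)cc2)c1/C=N/OCc1ccc([N+](=O)[O-])cc1` 24.6%
compound 2 `COc1cccc(CO/N=C/c2c(C)nn(C)c2Oc2ccccc2)c1` -19.6%

Compound 2 stands lowest of the two numbers; its nearest neighbour is compound 1, whose value lies higher by a gap beyond the scatter. Among the measured compounds shown here, no step between two compounds differing in one place is available. Compound 3 `Cc1nn(C)c(Oc2ccccc2)c1/C=N/OCc1ccc([N+](=O)[O-])cc1` is not yet measured. It differs from compound 2 by 4-nitrophenyl in place of 3-methoxyphenyl on a saturated chain carbon bound to an oxygen on an unsaturated carbon. Compound 3 shares the entering group with compound 1, so a rise is expected: the step of a number 29.6 percentage points higher from compound 2 to compound 3 (beyond the scatter) is estimated to lie beyond the scatter, upward. Compound 3 is expected to give 10%, within -15% to 35%.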

Compound 3, a percentage reported as inhibition, at one concentration (the size of the read-out at that concentration, not a potency): 18.3%
Estimate against measurement, compound 3: 8.3 percentage points below; the range from low to high includes it.
By their numbers in this assay, from the lowest: compound 2; then compounds 3 and 1 (each within the scatter of the next).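

With 4-nitrophenyl in place of 3-methoxyphenyl on a saturated chain carbon bound to an oxygen on an unsaturated carbon, this assay shows a number 37.9 percentage points higher from compound 2 to compound 3 (beyond the scatter) as a large step, so the read-out responds strongly to this exchange at this position. Hydrogen in place of chloro on an aromatic carbon gives a number 6.3 percentage points lower from compound 1 to compound 3 (within the scatter) and so no change that can be told apart.

As far as these compounds go, whether the large step follows the nitro group itself or its location on the ring stays open, as does what a 3-nitrophenyl or a 4-aminophenyl would give here. Nothing at hand bears on the cause of either step.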